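The source may hold more compounds than are shown below. What is called first, only, known or untested is meant among the compounds shown, and "the series" means these compounds.

Compound 1 `CNC(=O)c1cccnc1NCCCN1CCN(c2ccccc2OC)CC1`: 1 nM
Compound 2 `COc1ccccc1N1CCN(CCCNc2ccccc2C(=O)c2ccccc2)CC1`: 31.6 nM
Compound 3 `CN(C)C(=O)c1cccnc1NCCCN1CCN(c2ccccc2C#N)CC1`: 2 nM

All three were tested in a functional assay for antagonist activity at Alpha-1A adrenergic receptor (Oryctolagus cuniculus); on this read-out lower numbers stand for tighter binding and higher numbers for weaker binding. Compound 3 stands second highest of the three numbers. Its nearest neighbour is compound 1, whose number is lower by a margin that lies within the usual scatter, so the two cannot be told apart on this read-out. The furthest is compound 2, whose number is higher by a margin well beyond the scatter; compound 2 also differs in more than one place from compound 3, so no single change can be held responsible for that gap.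

Compound 4 `CN(C)C(=O)c1cccnc1NCCCN1CCN(c2ccccc2OCC2CC2)CC1` has not yet been measured. It differs from compound 3 in one place: cyclopropylmethoxy in place of cyano on an aromatic carbon. The rest of the structure, the shared core of compound 3 and compound 4, is unchanged.

Within the data shown here, no step between measured compounds that differ in one place is available, so the size of this step must be judged from what the three numbers show. Compound 1 carries an oxygen-linked group on the same kind of ring, and compound 1 gives 1 nM, a number within the scatter of compound 3. This suggests that an oxygen-linked group at that place is well tolerated. The step from compound 3 to compound 4 is therefore expected to be small, with no clear direction, and to stay within the scatter: no change at the digits printed from compound 3 to compound 4 (within the scatter). Compound 4 is expected to give about 2 nM, with a likely range from 0.6 nM to 7 nM.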

Compound 4, dissociation constant: 0.159 nM
For compound 4 the middle estimate is 13-fold (1.10 log units) above the measured one; the whole stated range lies above it.
By their numbers in this assay, from the lowest: compound 4; then compounds 1 and 3 (each within the scatter of the next); then compound 2.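

In this assay putting cyclopropylmethoxy in place of the nitrile on this aromatic carbon gives a 13-fold lower number from compound 3 to compound 4 (1.10 log units; beyond the scatter) and so shows that this one place on the shared core is far from neutral. The entering group has 5 heavy atoms against 2 for the cyano group and brings a three-membered carbon ring, yet the position accepts all of this, and the number moves towards tighter binding rather than weaker. Both groups count one hydrogen-bond acceptor, so that count does not separate compound 3 from compound 4, while the oxygen link, the ring and the number of heavy atoms all do.

Nothing shown here gives a reason for the size of this step. Going by these compounds, whether the step rests on the oxygen link, on the three-membered ring or on the length of the group stays open, and an ethoxy group or a cyclopropyl ring attached directly at this carbon, on the same core, would begin to pull these apart.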